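A few compounds are considered here, and "the series" means these few. Any claim that something is new, unique, unknown or untested is made for them only; others in the source may bear on it.

Compound 1 `CC[C@@H]1C(=O)N(C)c2cnc(-n3ccc4cc(F)ccc43)nc2N1C1CCCC1` stands at the higher of the two numbers recorded in a functional assay on Huh-7 cells (Homo sapiens) for antiproliferative activity, read by CCK-8 assay, with a stated time of 72 h (a higher number here means a weaker inhibitor of growth, a lower number a stronger inhibitor of growth), giving 16000 nM. Compound 2 `CCC1C(=O)N(C)c2cnc(Nc3ccc(S(=O)(=O)NCC(C)C)cc3)nc2N1c1ccn(C)n1` gives 8520 nM in this assay, and the gap between these two values lies within the scatter, so nothing separates them. Compound 3 `CC[C@@H]1C(=O)N(C)c2cnc(-n3ccc4cc(C(=O)NC(C)C)ccc43)nc2N1C1CCCC1` differs from compound 1 by isopropylcarbamoyl in place of fluoro on an aromatic carbon. Among the measured compounds shown here, no measured pair isolates a change of this kind, so the expected step is uncertain, and only a modest shift toward a lower number is estimated, as a 2.0-fold lower number from compound 1 to compound 3 (0.30 log units; within the scatter). Compound 3 is therefore expected to give about 8000 nM, between 2500 nM and 25000 nM.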

Compound 3, concentration for 50% growth inhibition: 1660 nM
The estimate for compound 3 lay 4.8-fold (0.68 log units) above the measured number; measured number below the stated range.
By their numbers in this assay, from the lowest: compound 3; then compounds 2 and 1 (each within the scatter of the next).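

On the aromatic carbon of the shared core's six-membered carbon ring, isopropylcarbamoyl in place of fluoro gives a 9.6-fold lower number from compound 1 to compound 3 (0.98 log units; beyond the scatter) in this assay and so shows that growth inhibition responds strongly to the group held at this position. This single step adds six heavy atoms at once, so it cannot assign the change to any one part of the new group. Nothing measured accounts for the gain.

From the compounds shown here alone, whether a smaller methylamide, a carboxylic acid or an amine at this carbon would give a similar number remains open, as does whether a longer chain on the amide nitrogen would go further.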